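A few compounds are considered here, and "the series" means these few. Any claim that something is new, unique, unknown or untested is made for them only; others in the source may bear on it.

Three compounds share a core built from a thiazolone joined to an oxindole, and they differ in the groups hung on it. Compound 1 `COc1ccc(C2=NN(C3=NC(=O)/C(=C4\C(=O)Nc5ccc(Br)cc54)S3)C(c3ccc(Cl)cc3)C2)cc1` and compound 2 `COc1ccc(C2=NN(C3=NC(=O)/C(=C4\C(=O)Nc5ccc(Cl)cc54)S3)C(c3ccc(Cl)cc3)C2)cc1` carry a methoxyphenyl and a chlorophenyl on their pyrazoline ring; compound 3 `CN(C)c1ccc(C2CC(c3ccccc3)=NN2C2=NC(=O)/C(=C3\C(=O)Nc4ccc(Br)cc43)S2)cc1` carries instead a dimethylaminophenyl and a plain phenyl, and the difference between the two cores is not broken down here. In a functional assay on cells (Cancer cell lines, Homo sapiens) for cytotoxicity, read by sulforhodamine B assay, with a stated time of 48 h (on this read-out higher numbers stand for weaker inhibition of growth and lower numbers for stronger inhibition of growth), compound 1 gives 190 nM, compound 2 gives 270 nM, and compound 3 gives 250 nM.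

Going by the values given here, the one counted change within this set is chloro in place of bromo on an aromatic carbon, which brought a 1.4-fold higher number from compound 1 to compound 2 (0.15 log units; within the scatter). Compound 4 `CN(C)c1ccc(C2CC(c3ccccc3)=NN2C2=NC(=O)/C(=C3\C(=O)Nc4ccc(Cl)cc43)S2)cc1` is the still unmeasured partner of compound 3 and carries exactly the same change, (chloro in place of bromo on an aromatic carbon), at the same place on the oxindole ring.

Among the compounds with values here, since the only precedent for this exchange is the step from compound 1 to compound 2, compound 4 is expected to land close to compound 3, with an estimated step of a 1.3-fold higher number from compound 3 to compound 4 (0.12 log units; within the scatter). The estimated value for compound 4 is therefore 330 nM, likely between 170 nM and 650 nM.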

Compound 4, concentration for 50% growth inhibition: 240 nM
Beside the measured number, compound 4's estimate is 1.4-fold (0.14 log units) above it; the range from low to high includes it.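

In this assay, chloro in place of bromo on the aromatic carbon brought a 1.0-fold lower number from compound 3 to compound 4 (0.02 log units; within the scatter), so on this second core the exchange again stayed within the scatter. Going by these compounds alone, with only two pairs, this does not show that the same would hold on any other core, and since neither step stands clear of the scatter, it does not show that bromo and chloro differ at all in this assay. Set side by side, the two steps agree as far as this read-out can tell, so the exchange carried over from one core to the other: the same change on two cores in this assay, a 1.4-fold higher number (0.15 log units; within the scatter) from compound 1 to compound 2 and a 1.0-fold lower number (0.02 log units; within the scatter) from compound 3 to compound 4, 1.5-fold (0.17 log units) apart, within the scatter of two such steps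

The compounds shown hold only bromo and chloro at this place, so it stays open whether fluoro, methyl, methoxy or an amine there would give a number beyond the scatter. Going by these compounds, the two cores also differ in more than one place, so it is open how the methoxyphenyl and chlorophenyl pair or the dimethylaminophenyl and plain phenyl pair each bear on the number.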